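This account rests on a few compounds, and the source may have more. Where it says the series, first, only, none or still open, it means among the compounds named here.

In an ADME assay on the whole organism (Mus musculus, strain Swiss Webster) for pharmacokinetics, read by LC-MS, at a dose of 50 mg/kg by the oral route (a higher number here means more compound in the circulation at the dose given, a lower number less compound in the circulation), two compounds sharing one core have been measured so far. Compound 1 `O=C(Nc1ccc(F)c(-c2nc3ncc(-c4ccc(F)c(F)c4)cc3[nH]2)c1)N1CCCC1` gives 12000 ng.h/mL, and compound 2 `O=C(Nc1ccc(F)c(-c2nc3ncc(-c4cc(F)ccc4F)cc3[nH]2)c1)N1CCCC1` gives 5620 ng.h/mL, the lower of the two numbers. Compound 3 `O=C(Nc1ccc(F)c(-c2nc3ncc(-c4ccc(F)cc4F)cc3[nH]2)c1)N1CCCC1` has yet to be measured in this assay. It differs from compound 2 as follows: 2,4-difluorophenyl in place of 2,5-difluorophenyl on an aromatic carbon. In short, it carries 2,4-difluorophenyl in place of 2,5-difluorophenyl on an aromatic carbon. Among the compounds with values here, one measured step bears on this change: a 2.1-fold lower number from compound 1 to compound 2 (0.33 log units; beyond the scatter), a modest step with 2,5-difluorophenyl in place of 3,4-difluorophenyl on that same carbon. This single step suggests a likely size but fixes no direction. A shift of that size or smaller is therefore expected, leaning slightly upward, and the estimated step is a 1.2-fold higher number from compound 2 to compound 3 (0.10 log units; within the scatter). The estimate for compound 3 is 7000 ng.h/mL, with an expected range of 2800 ng.h/mL to 17000 ng.h/mL.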

Compound 3, area under the concentration-time curve: 15600 ng.h/mL
For compound 3 the middle estimate is 2.2-fold (0.35 log units) below the measured one, and the stated range covers the measured number.
By their numbers in this assay, from the lowest: compound 2; then compounds 1 and 3 (each within the scatter of the next).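

In this assay, the two isomers now give steps of opposite direction at this position on the shared core: 2,4-difluorophenyl in place of 2,5-difluorophenyl gives a 2.8-fold higher number from compound 2 to compound 3 (0.44 log units; beyond the scatter), which runs against a 2.1-fold lower number from compound 1 to compound 2 (0.33 log units; beyond the scatter). Among these three compounds, which carry the same atoms joined differently, 2,5-difluorophenyl alone stands apart, while 2,4-difluorophenyl in place of 3,4-difluorophenyl gives a 1.3-fold higher number from compound 1 to compound 3 (0.11 log units; within the scatter), so these two cannot be told apart here. No measurement at hand says why the placing of the fluorines matters in this way. The compounds shown leave open how a phenyl ring with a single fluorine, or one carrying a methoxy group or an amine, would read at this carbon. They also leave open whether the same placing of the fluorines would matter on a different core.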